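Compound 4 Weighed Against Three Measured Neighbours

The compounds below may be only part of what the source reports. "The series", "measured", "known", "first", "only" and "open" are said of these compounds alone.

Compound 3 `CC1(C)CC(=O)N(c2cnc(NCc3c(F)ccc4c3CCO4)n3cnnc23)C1` gives 16 mL.min-1.g-1 in an ADME assay on microsomes from liver (Homo sapiens) for metabolic stability, read by LC-MS, using NADPH, with stated times of 5 min and 30 min, tested at 1 uM (on this read-out higher numbers stand for fast clearance and lower numbers for slow clearance), the second highest of the three numbers. Its nearest neighbour is compound 1 `O=C(Nc1cnc(NCc2c(F)ccc3c2CCO3)n2cnnc12)c1ccccc1`, which in this assay gives 10 mL.min-1.g-1 (a 1.6-fold higher number from compound 1 to compound 3 (0.20 log units; within the scatter)), and its furthest is compound 2 `CN(c1ccccc1)c1cnc(NCc2c(F)ccc3c2CCO3)n2cnnc12`, which in this assay gives 55 mL.min-1.g-1 (a 3.4-fold lower number from compound 2 to compound 3 (0.54 log units; beyond the scatter)). Compound 4 `CN(c1ncco1)c1cnc(NCc2c(F)ccc3c2CCO3)n2cnnc12` differs from compound 3 in one place: methyl(1,3-oxazol-2-yl)amino in place of 4,4-dimethyl-2-oxopyrrolidin-1-yl on an aromatic carbon. The step already shown between compound 2 and compound 3 bears most on this change, since the methyl(1,3-oxazol-2-yl)amino of compound 4 resembles the methyl(phenyl)amino of compound 2; read in reverse it points to a modest rise. The entering ring is an oxazole rather than a phenyl, and the expected rise is set smaller than that step. Compound 4 is therefore expected to show a 1.9-fold higher number from compound 3 to compound 4 (0.27 log units; within the scatter). The estimate for compound 4 is 30 mL.min-1.g-1, with a range from 12 mL.min-1.g-1 to 70 mL.min-1.g-1.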

Compound 4, intrinsic clearance in microsomes: 11 mL.min-1.g-1
Estimate against measurement, compound 4: 2.7-fold (0.44 log units) above, outside the stated range (below it).
By their numbers in this assay, from the lowest: compounds 1, 4 and 3 (each within the scatter of the next); then compound 2.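

In this assay, 1,3-oxazol-2-yl in place of phenyl on the nitrogen gives a 5.0-fold lower number from compound 2 to compound 4 (0.70 log units; beyond the scatter) and so shows that the methyl-bearing nitrogen alone does not carry the high number of compound 2. With a 1.5-fold lower number from compound 3 to compound 4 (0.16 log units; within the scatter) and a 1.1-fold higher number from compound 1 to compound 4 (0.04 log units; within the scatter) both within the scatter, methyl(1,3-oxazol-2-yl)amino stands level with the lactam and the benzamido at this position. No measurement at hand accounts for the difference between the two rings. Open, on these data alone, is whether a pyridin-2-yl on that nitrogen would stay with compound 4 or go with compound 2. Also open, as far as these compounds go, is what replacing the methyl with an ethyl would do.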